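A few compounds are considered here, and "the series" means these few. Any claim that something is new, unique, unknown or untested is made for them only; others in the source may bear on it.

Compound 1 `Oc1cccc(-c2cc(-c3ccncc3)nc(-c3ccccc3Cl)c2)c1`: 0%
Compound 2 `Oc1cccc(-c2cc(-c3ccsc3)nc(-c3cccc(Cl)c3)c2)c1`: 26.2%
Compound 3 `Oc1ccc(-c2cc(-c3ccco3)nc(-c3ccccc3Cl)c2)cc1`: 3.9%

In an assay on isolated protein for inhibition of DNA topoisomerase 1 (Homo sapiens), with a stated time of 30 min, tested at 100 uM (on this read-out higher numbers stand for a stronger effect at the one concentration tested and lower numbers for a weaker effect), compound 1 gives 0%, the smallest of the three numbers shown. Compound 3 gives 3.9%, which lies within the scatter of compound 1, while compound 2 gives 26.2%, beyond the scatter above it. Compound 4 `Oc1cccc(-c2cc(-c3ccccn3)nc(-c3ccccc3Cl)c2)c1` is the next compound to be tested in this assay. It differs from compound 1 by one change: pyridin-2-yl in place of pyridin-4-yl on an aromatic carbon. Among the compounds with values here, no pair of measured compounds differs in only one place, so no measured step guides this change. Compound 4 is therefore expected to stay near compound 1, with a step of a number 5 percentage points higher from compound 1 to compound 4 (within the scatter) that is expected to lie within the scatter. Compound 4 is estimated to give 5%, with a range from 0% to 20%.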

Compound 4, a percentage reported as inhibition, at one concentration (the size of the read-out at that concentration, not a potency): 0%
Compound 4: middle estimate off by 5 percentage points, on the high side; low and high end bracket the measured number.
By their numbers in this assay, from the lowest: compounds 1, 4 and 3 (each within the scatter of the next); then compound 2.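

Putting pyridin-2-yl in place of pyridin-4-yl on this aromatic carbon produces no change at the digits printed from compound 1 to compound 4 (within the scatter), the first step read at this position in this assay. With the 2-chlorophenyl and 3-hydroxyphenyl groups held constant, this shift of the ring nitrogen therefore leaves the read-out unmoved at the one concentration tested. Nothing available explains this result.

The compounds shown leave open whether a pyridin-3-yl group or a simple amine at this position would give a different read-out. They also leave open whether the pyridin-2-yl for pyridin-4-yl change would be equally silent with the hydroxyl or chlorine placed elsewhere.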